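The compounds below may be only part of what the source reports. "The series", "measured", "known", "first", "only" and "open" are said of these compounds alone.

In a functional assay on MC-38 cells (Mus musculus) for antiproliferative activity, read by colorimetric assay and MTT assay (a higher number here means a weaker inhibitor, a lower number a stronger inhibitor), compound 1 (`COc1ccc(S(=O)(=O)Nc2ccc(Cl)c3cc[nH]c23)cc1`) gives 0.65 ug/mL, and compound 2 (`O=S(=O)(Nc1cccc2cc[nH]c12)c1ccc(Cl)cc1`) gives 7 ug/mL. That is the higher of the two numbers, so compound 2 is the weaker inhibitor, by a gap beyond the usual scatter. Compound 3 (`O=S(=O)(Nc1ccc(Cl)c2cc[nH]c12)c1ccc(Cl)cc1`) has chloro in place of hydrogen on an aromatic carbon of compound 2: chloro in place of hydrogen on an aromatic carbon. Going by the values given here, no measured pair shows this change alone, so the only guide is compound 1 at 0.65 ug/mL. A step of a 7.0-fold lower number from compound 2 to compound 3 (0.85 log units; beyond the scatter) is expected, towards a lower number and beyond the scatter. For compound 3 the estimated value is 1 ug/mL, with an expected range of 0.3 ug/mL to 3 ug/mL.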

Compound 3, half-maximal inhibitory concentration: 0.66 ug/mL
Beside the measured number, compound 3's estimate is 1.5-fold (0.18 log units) above it, within the range that was stated.
By their numbers in this assay, from the lowest: compounds 1 and 3 (each within the scatter of the next); then compound 2.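

With chloro in place of hydrogen on the aromatic carbon para to a large group, this assay shows an 11-fold lower number from compound 2 to compound 3 (1.03 log units; beyond the scatter) as a large step, so this single atom change alone carries a clear difference in the read-out. Chloro in place of methoxy on an aromatic carbon gives a 1.0-fold higher number from compound 1 to compound 3 (0.01 log units; within the scatter) and so separates these two groups by nothing that this assay can resolve. No measurement shown here offers a reason for either step. As far as these compounds go, whether fluoro, bromo or an amine on the chloro-bearing carbon of compound 3 would hold the same level remains open.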